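Swapping Phenyl for Acetyl on a Shared Core

This account rests on a few compounds, and the source may have more. Where it says the series, first, only, none or still open, it means among the compounds named here.

Measured compounds:
Compound 1, `O=[N+]([O-])c1ccc2nc(-c3ccccc3Cl)[nH]c2c1`, gives 10700 nM in a functional assay for antagonist activity at Neuropeptides B/W receptor type 1 (Homo sapiens), read by cAMP accumulation; on this read-out lower numbers stand for stronger inhibition and higher numbers for weaker inhibition.
Compound 2, `O=[N+]([O-])c1ccc2[nH]c(-c3ccc(-c4ccccc4)cc3)nc2c1`, gives 4880 nM in this assay.
Compound 3, `Cc1cc(Cl)ccc1-c1nc2cc([N+](=O)[O-])ccc2[nH]1`, gives 2490 nM in this assay.

Among the three numbers, compound 2 holds the second highest. Its nearest neighbour is compound 3, whose number is lower but within the scatter of compound 2, so no order between the two can be claimed. Compound 1 lies further off, with a higher number than compound 2 that is beyond the scatter.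

Compound 4, `CC(=O)c1ccc(-c2nc3cc([N+](=O)[O-])ccc3[nH]2)cc1`, has not yet been measured. It differs from compound 2 in one place: acetyl in place of phenyl on an aromatic carbon. For the measured compounds named here, no step between two measured compounds matches this change, so nothing in the measured set shows what an acetyl in place of a phenyl does here.

With that gap in the data, compound 4 is expected to come out close to compound 2, with a step in this assay of a 1.1-fold higher number from compound 2 to compound 4 (0.05 log units; within the scatter), which means no change beyond the scatter is expected in either direction. Compound 4 is therefore estimated at 5500 nM, with a range from 1800 nM to 17000 nM.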

Compound 4, half-maximal inhibitory concentration: 9320 nM
For compound 4 the middle estimate is 1.7-fold (0.23 log units) below the measured one; the range from low to high includes it.
By their numbers in this assay, from the lowest: compounds 3, 2, 4 and 1 (each within the scatter of the next, the first and the last beyond it).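

In this assay, the swap of phenyl for acetyl on an aromatic carbon, para to a large group, gives a 1.9-fold higher number from compound 2 to compound 4 (0.28 log units; within the scatter), so no change can be claimed for it. For the compounds shown here, this is the first view of this position that the measured compounds offer: the outer six-membered aromatic ring of compound 2 can give way to acetyl, which has no ring, 3 heavy atoms and 1 hydrogen-bond acceptor, without a shift beyond the scatter. The data offer nothing that would explain this outcome.

As far as these compounds go, what remains open is whether any other group at this position, such as an amine, a carboxylic acid or a longer chain, would move the number beyond the scatter in either direction. It is also open whether acetyl in place of phenyl would have the same small effect on another member of the series, since the compounds shown contain only this one pair that differs in a single place.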